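Shifting the aryl group on the triazole of a bicyclic lactam

The source may report more compounds than this note shows. Statements on the series, on what has been measured and on what is new or still open speak of the compounds shown alone.

Measured compounds:
Compound 1, `CC1(C)[C@H]2CC[C@]1(C)N(Cc1cn(-c3ccccc3O)nn1)C(=O)C2`, 230 nM
Compound 2, `COc1ccc(-n2cc(CN3C(=O)C[C@@H]4CC[C@@]3(C)C4(C)C)nn2)cc1`, 50 nM
Compound 3, `CC1(C)[C@H]2CC[C@]1(C)N(Cc1cn(-c3ccccc3Br)nn1)C(=O)C2`, 130 nM

All three were tested in a functional assay on A549 cells (Homo sapiens) for inhibition, read by MTT assay, with a stated time of 24 h; on this read-out lower numbers stand for stronger inhibition and higher numbers for weaker inhibition. Compound 3 gives 130 nM, the second highest of the three numbers: the gap to compound 1 is within the scatter, while compound 2 sits well below it. The next compound, compound 4, `CC1(C)[C@H]2CC[C@]1(C)N(Cc1cn(-c3ccc(F)cc3)nn1)C(=O)C2`, differs from compound 3 in one place: 4-fluorophenyl in place of 2-bromophenyl on an aromatic nitrogen.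

Two of the measured steps bear on this change. The step of a 2.6-fold higher number from compound 2 to compound 3 (0.41 log units; beyond the scatter) shows that exchanging 4-methoxyphenyl for 2-bromophenyl raised the number modestly, and the step of a 4.6-fold lower number from compound 1 to compound 2 (0.66 log units; beyond the scatter) shows that 4-methoxyphenyl also gave a lower number than 2-hydroxyphenyl. The step of a 1.8-fold lower number from compound 1 to compound 3 (0.25 log units; within the scatter), by contrast, stayed within the scatter. Compound 4 carries 4-fluorophenyl, which in name resembles the 4-methoxyphenyl of compound 2 more than the groups of compounds 1 and 3, so a modest drop is expected rather than a large one. Compound 4 is therefore expected to show a 1.9-fold lower number from compound 3 to compound 4 (0.27 log units; within the scatter). For compound 4 the estimate is 70 nM, with a range from 30 nM to 160 nM.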

Compound 4, half-maximal inhibitory concentration: 230 nM
Compound 4: the middle estimate sits 3.3-fold (0.52 log units) below what was measured, and the stated range ends below it.
By their numbers in this assay, from the lowest: compound 2; then compounds 3, 1 and 4 (each within the scatter of the next).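

Moving to the 4-fluorophenyl group gives, in this assay, a step that can be read as a 1.8-fold higher number from compound 3 to compound 4 (0.25 log units; within the scatter) and, against the hydroxy compound, no change at the digits printed from compound 1 to compound 4 (within the scatter), so compounds 1, 3 and 4 cannot be told apart on this read-out. Having a group named at the 4 position of the phenyl ring is therefore not enough to match compound 2: fluoro in place of methoxy gives a 4.6-fold higher number from compound 2 to compound 4 (0.66 log units; beyond the scatter), which leaves compound 2 alone with its lower number and makes compound 4 the case that goes against any reading based on the 4-substituted ring alone. No measurement here offers an explanation for the gap between the methoxy and fluoro compounds.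

The compounds shown leave open whether the lower number of compound 2 is tied to methoxy itself or would also appear with a longer chain such as 4-ethoxyphenyl, or with an amine as in 4-aminophenyl. They also leave open whether methoxy would give the same number as 2-methoxyphenyl, the position held by the bromo of compound 3.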